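Two Inactive Limits and a Chlorophenyl Replacement

The source may hold more compounds than are shown below. What is called first, only, known or untested is meant among the compounds shown, and "the series" means these compounds.

Two measured compounds share one core and were tested in a functional assay on MCF7 cells (Homo sapiens) for cytotoxicity, read by MTT assay, with a stated time of 72 h; a higher number here means a weaker inhibitor, a lower number a stronger inhibitor. Compound 1, `CCCCCCCCCCCCNc1nc(SCc2ccc(C(F)(F)F)cc2)nc2ccccc12`, carries a long alkyl chain on the amine nitrogen. In this assay compound 1 gives > 50000 nM, which is a limit of the assay and not a number. Compound 2, `FC(F)(F)c1ccc(CSc2nc(Nc3ccccc3C(F)(F)F)c3ccccc3n2)cc1`, instead bears an aryl group on that nitrogen. In this assay compound 2 likewise returns only > 50000 nM, again a limit rather than a measured value. Both results therefore stand at the limit of > 50000 nM in this assay, at which 2 of the 2 values shown sit. Compound 3, `FC(F)(F)c1ccc(CSc2nc(Nc3cccc(Cl)c3)c3ccccc3n2)cc1`, differs from compound 2 in a single place: 3-chlorophenyl in place of 2-(trifluoromethyl)phenyl on a nitrogen on an aromatic ring. Among the measured compounds shown here, no measured step between neighbouring compounds exists here, so no precedent sets the size of this change. Because compound 2 sits at > 50000 nM, no number is available to move from. Compound 3 is expected to stay weak, estimated at 50000 nM within a range of 15000 nM to 150000 nM. The implied step, a number no higher from compound 2 to compound 3 (the limit leaves the size open), is expected to be none beyond the scatter.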

Compound 3, half-maximal inhibitory concentration: 25100 nM
Compound 3: middle estimate off by 2.0-fold (0.30 log units), on the high side, within the range that was stated.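

With 3-chlorophenyl on the nitrogen, compound 3 gives the only value of the three shown that is a number and not a limit, so this position can carry a group that reads inside the range of this assay. The replacement of 2-(trifluoromethyl)phenyl by 3-chlorophenyl gives an at least 1.9-fold lower number from compound 2 to compound 3 (0.29 log units; that floor lies within the scatter), so the change cannot yet be told apart from repeat scatter. The full size of the step stays unknown because its starting point is a limit and not a number: the limit of > 50000 nM in this assay, at which 2 of the 3 values shown sit.

The swap removes the trifluoromethyl group and brings in the chlorine in a single step, so the compounds shown do not separate the two. They also leave open how an unsubstituted phenyl, a methoxy group or a carboxylic acid on that ring would read.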